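Methoxy for fluoro on the pyrazole aryl arm

The compounds below may be only part of what the source reports. "The series", "measured", "known", "first", "only" and "open" are said of these compounds alone.

Compound 1, `Fc1ccc(-c2cc(-c3ccc4cc(F)ccc4n3)n(-c3ccccc3)n2)cc1`, gives 87.5% in an ADME assay on Huh-7 cells (Homo sapiens) for cytotoxicity, read by XTT assay, with a stated time of 3 days, tested at 200 uM; a lower number here means a stronger effect, a higher number a weaker effect of the compound at the concentration tested.
Compound 2, `COc1ccc(-c2cc(-c3ccc4cc(F)ccc4n3)n(-c3ccccc3)n2)cc1`, gives 98.9% in this assay.
Compound 3, `Fc1ccc(-c2cc(-c3ccc4cc(F)ccc4n3)n(-c3ccc(F)cc3)n2)cc1`, gives 86.5% in this assay.

The three measured compounds share one core and differ only in the groups on two phenyl rings. Compound 2 differs from compound 1 by methoxy in place of fluoro on an aromatic carbon, and this change gave a number 11.4 percentage points higher from compound 1 to compound 2 (beyond the scatter). Compound 3 differs from compound 1 by fluoro in place of hydrogen on an aromatic carbon, and that change gave a number 1 percentage points lower from compound 1 to compound 3 (within the scatter), so compound 1 and compound 3 are not separated by this assay. Compound 3 has the lowest number of the three, yet only its gap to compound 2 lies beyond the scatter.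

Compound 4, `COc1ccc(-c2cc(-c3ccc4cc(F)ccc4n3)n(-c3ccc(F)cc3)n2)cc1`, has not yet been measured in this assay. It differs from compound 3 by methoxy in place of fluoro on an aromatic carbon. Among the compounds with values here, this is the same change as the one from compound 1 to compound 2, made on the core of compound 3 instead of that of compound 1. Because that change gave a number 11.4 percentage points higher from compound 1 to compound 2 (beyond the scatter), the expected step here is a number 11 percentage points higher from compound 3 to compound 4 (beyond the scatter). This rests on a single measured instance of the change, so it is only a modest basis.

Compound 4 is therefore estimated at 97.5% in this assay, with a likely range from 88% to 106%.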

Compound 4, a percentage reported as activity, at one concentration (the size of the read-out at that concentration, not a potency): 95.4%
Beside the measured number, compound 4's estimate is 2.1 percentage points above it; measured number inside the range.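

In this assay, methoxy in place of fluoro gave a number 8.9 percentage points higher from compound 3 to compound 4 (within the scatter), and this step cannot be told apart from the same change on the core of compound 1: the same change on two cores in this assay, a number 11.4 percentage points higher (beyond the scatter) from compound 1 to compound 2 and a number 8.9 percentage points higher (within the scatter) from compound 3 to compound 4, 2.5 percentage points apart, within the scatter of two such steps. Fluoro in place of hydrogen on an aromatic carbon gave a number 3.5 percentage points lower from compound 2 to compound 4 (within the scatter), and this step likewise agrees with its earlier counterpart: the same change on two cores in this assay, a number 1 percentage points lower (within the scatter) from compound 1 to compound 3 and a number 3.5 percentage points lower (within the scatter) from compound 2 to compound 4, 2.5 percentage points apart, within the scatter of two such steps. The two changes therefore carried from one core to the other with no detectable difference in size, but the methoxy step on the core of compound 3 does not itself clear the scatter, and two instances in one assay at one concentration neither establish a rule for other cores in this series nor explain the result.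

The compounds shown leave open whether other groups in the same place on the 4-fluorophenyl arm, such as an amine, a carboxylic acid or a longer chain like butoxy, would shift the number as methoxy does. They also leave open what a change elsewhere on the shared core would do, since the fluoro on that core is the same in all four compounds.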